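Swapping 2,4-dimethoxyphenyl for 2-bromo-4-fluorophenyl at the assay limit

This account rests on a few compounds, and the source may have more. Where it says the series, first, only, none or still open, it means among the compounds named here.

Of the compounds shown here, two with a shared core have been tested so far in a functional assay on A549 cells (Homo sapiens) for antiproliferative activity, read by MTT assay; a lower number here means a stronger inhibitor, a higher number a weaker inhibitor. Compound 1 `Cn1c(=O)c(=O)n(C2CCCC2)c2nc(N/N=C/c3ccco3)ncc21` gives > 100000 nM, which is a limit of the assay and not a number. Compound 2 `COc1ccc(/C=N/Nc2ncc3c(n2)n(C2CCCC2)c(=O)c(=O)n3C)c(OC)c1` gives > 100000 nM, which is likewise a limit and not a number. That is where compound 2 stands, and the whole record is short: the limit of > 100000 nM in this assay, at which 2 of the 2 values shown sit.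

Compound 3 `Cn1c(=O)c(=O)n(C2CCCC2)c2nc(N/N=C/c3ccc(F)cc3Br)ncc21` keeps the core of compound 2 and changes one group: 2-bromo-4-fluorophenyl in place of 2,4-dimethoxyphenyl on a carbon with a double bond to nitrogen. The new group is still a six-membered aromatic ring of carbon only, but it carries fluorine and bromine where the old one carried two oxygen-linked groups.

Within the data shown here, the one measured step that bears on this is a step that the two limits leave unreadable from compound 1 to compound 2. It has no readable size or direction, so it gives no step size to carry over, and this assay offers no firm expectation of a change. The estimated step is a number no higher from compound 2 to compound 3 (the limit leaves the size open). For compound 3 the expected value is 100000 nM, with an estimated range from 20000 nM to 300000 nM, and a report of only a limit again is the likeliest outcome.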

Compound 3, half-maximal inhibitory concentration: 6590 nM
Beside the measured number, compound 3's estimate is 15-fold (1.18 log units) above it, and the stated range ends above it.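

In this assay, the group on the carbon with a double bond to nitrogen proves able to shift the result: 2-bromo-4-fluorophenyl gives an at least 15-fold lower number from compound 2 to compound 3 (1.18 log units; beyond the scatter), and set against furan-2-yl it gives an at least 15-fold lower number from compound 1 to compound 3 (1.18 log units; beyond the scatter). Among these compounds, the earlier pair could not show this, since the step between those two compounds cannot be read, and compound 3 is now the only compound of the three with a real number rather than a limit: the limit of > 100000 nM in this assay, at which 2 of the 3 values shown sit. Both new steps are minimum sizes, so they show that the change matters and in which direction, but not how large the full effect is.

The change brings in fluorine and bromine together and removes both methoxy groups at once, so these compounds cannot tell which of those differences accounts for the lower number. As far as these compounds go, it also remains open whether a phenyl ring carrying only fluorine or only bromine, or a different group such as a chlorine atom, a nitrile or an amine, would give a similar, stronger or weaker result.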